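A few compounds are considered here, and "the series" means these few. Any claim that something is new, unique, unknown or untested is made for them only; others in the source may bear on it.

Working notes on the series.

Compound 1 `N#Cc1ccc(SCc2ccccc2)cc1` gives 42400 nM in an assay on microsomes for inhibition of Amine oxidase [flavin-containing] A (Homo sapiens), read by fluorescence and spectrophotometry, with a stated time of 20 min; on this read-out lower numbers stand for stronger inhibition and higher numbers for weaker inhibition. Among the compounds with values here, compound 2 `N#Cc1ccc(SCc2ccc(Cl)cc2)cc1` gives 20300 nM, and the step of a 2.1-fold lower number from compound 1 to compound 2 (0.32 log units; beyond the scatter) is the one change tracked here: chloro in place of hydrogen on an aromatic carbon.

Compound 3 `N#Cc1ccc(Sc2ccccc2)cc1` is the second core; how it differs from compound 1 is not broken down here. In this assay compound 3 gives 36900 nM, and against compound 1 the two numbers lie within the scatter, so nothing is said of their order.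

Compound 4 `N#Cc1ccc(Sc2ccc(Cl)cc2)cc1` is not yet measured. It stands to compound 3 as compound 2 stands to compound 1: chloro in place of hydrogen on an aromatic carbon. The place is not the same word for word: in compound 2 the chloro sits para to a large group, in compound 4 para to a group of 9 heavy atoms, so this is the same kind of change, not the same. Within the data shown here, the one measured step of this kind, a 2.1-fold lower number from compound 1 to compound 2 (0.32 log units; beyond the scatter), is modest but beyond the scatter, and it is the only precedent available. A step of roughly that size is expected from compound 3 to compound 4 in this assay, a 2.1-fold lower number from compound 3 to compound 4 (0.31 log units; beyond the scatter), with wider uncertainty because the core differs and the change has been seen only once. For compound 4 the estimate is 18000 nM, spanning 9000 nM to 40000 nM.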

Compound 4, half-maximal inhibitory concentration: 18200 nM
Beside the measured number, compound 4's estimate is 1.0-fold (0.00 log units) below it; low and high end bracket the measured number.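

In this assay the chloro change carries over to the second core, with a 2.0-fold lower number from compound 3 to compound 4 (0.31 log units; beyond the scatter). Set beside the earlier step, the size holds from the core of compound 1 to the core of compound 3: the same change on two cores in this assay, a 2.1-fold lower number (0.32 log units; beyond the scatter) from compound 1 to compound 2 and a 2.0-fold lower number (0.31 log units; beyond the scatter) from compound 3 to compound 4, 1.0-fold (0.01 log units) apart, within the scatter of two such steps. Within the data shown here, this shows that, on these two cores, chloro in place of hydrogen gives a modest step of matching size, but it rests on only two pairs with one entering group, and it does not show that the step would hold on any other core.

The compounds shown leave open whether another group in the same place, such as a methoxy, an amine or a carboxylic acid, would give a step of like size or direction. Also open, going by these compounds, are how the numbers would respond to a longer chain on the sulfur and whether the nitrile could be replaced by an amide.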